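Naphthalen-1-yl for pyridin-3-yl at the Ring Amine Nitrogen

The source may report more compounds than this note shows. Statements on the series, on what has been measured and on what is new or still open speak of the compounds shown alone.

Compound 1, `Nc1scc(CN2CCN(c3cc(Cl)cc(Cl)c3)CC2)c1C(=O)c1ccc(Cl)cc1`, in a functional assay on CHO cells with adenosine receptor A1 (Homo sapiens) as the target, read by cAMP accumulation and immunoassay, with a stated time of 6 min, tested at 0.01 uM; on this read-out higher numbers stand for a weaker effect at the one concentration tested and lower numbers for a stronger effect: compound 1 gives -1%.
Compound 2, `Nc1scc(CN2CCN(c3ccc([N+](=O)[O-])cc3)CC2)c1C(=O)c1ccc(Cl)cc1`: compound 2 gives -12%.
Compound 3, `Nc1scc(CN2CCN(c3cccnc3)CC2)c1C(=O)c1ccc(Cl)cc1`: compound 3 gives 3.2%.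

Compound 3 gives the highest of these three numbers. Its gap to compound 1 is within the scatter, a number 4.2 percentage points higher from compound 1 to compound 3 (within the scatter), and only its gap to compound 2 is beyond it, a number 15.2 percentage points higher from compound 2 to compound 3 (beyond the scatter). All three compounds share one core and differ only in the aryl group on an amine nitrogen in a ring.

Compound 4, `Nc1scc(CN2CCN(c3cccc4ccccc34)CC2)c1C(=O)c1ccc(Cl)cc1`, continues that series. Its change from compound 3 is naphthalen-1-yl in place of pyridin-3-yl on an amine nitrogen in a ring.

Within the data shown here, three measured steps bear on this, each a swap of the aryl group at the same ring amine nitrogen: a number 11 percentage points lower from compound 1 to compound 2 (beyond the scatter), a number 4.2 percentage points higher from compound 1 to compound 3 (within the scatter) and a number 15.2 percentage points higher from compound 2 to compound 3 (beyond the scatter). Two are modest and one is within the scatter; none concerns naphthalen-1-yl, and all three numbers sit close to zero. The step from compound 3 to compound 4 in this assay is therefore expected to stay within the scatter, with no clear direction, as a number 1.2 percentage points lower from compound 3 to compound 4 (within the scatter).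

Compound 4 is estimated at 2%, between -12% and 16%.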

Compound 4, a percentage reported as activity, at one concentration (the size of the read-out at that concentration, not a potency): 8.7%
Beside the measured number, compound 4's estimate is 6.7 percentage points below it, within the range that was stated.
By their numbers in this assay, from the lowest: compound 2; then compounds 1, 3 and 4 (each within the scatter of the next).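

In this assay, this place on the ring amine nitrogen accepts naphthalen-1-yl, with its 2 six-membered aromatic rings of carbon only, without a shift that can be told from the scatter: a number 5.5 percentage points higher from compound 3 to compound 4 (within the scatter), and a number 9.7 percentage points higher from compound 1 to compound 4 (within the scatter). Thus, loss of the ring nitrogen and the hydrogen-bond acceptor of pyridin-3-yl has no resolved effect on this read-out, and the larger aryl group does not separate compound 4 from compound 1 or compound 3. Only compound 2, with 4-nitrophenyl, stands apart from each of the other three compounds, now also by a number 20.7 percentage points higher from compound 2 to compound 4 (beyond the scatter); what lies behind these numbers is not addressed by any measurement at hand.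

From the compounds shown here alone, it remains open whether a saturated ring such as cyclohexyl, or a benzyl group, would be tolerated on this nitrogen, and whether a carboxylic acid or an amine on the aryl ring would move the number away from those of compounds 1, 3 and 4. With one concentration read, the compounds also leave their potencies open.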